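This account rests on a few compounds, and the source may have more. Where it says the series, first, only, none or still open, it means among the compounds named here.

Compound 3, whose structure is `O=[N+]([O-])c1cn2c(n1)OC(COc1cccc(-c3ccc(F)nc3)n1)CC2`, is the point of departure. In an ADME assay on MRC5 cells (Homo sapiens) for cytotoxicity, read by resazurin assay, with a stated time of 72 h (on this read-out lower numbers stand for stronger inhibition and higher numbers for weaker inhibition), compound 3 gives 35000 nM, the lowest of the two numbers measured in this series. Its closest neighbour is compound 2, with the structure `O=[N+]([O-])c1cn2c(n1)OC(COc1cccc(-c3ccc(F)cc3)n1)CC2`, which in this assay gives 59000 nM; the step of a 1.7-fold lower number from compound 2 to compound 3 (0.23 log units; within the scatter) separates the two, so neither can be called the stronger. Compound 1, with the structure `CC1(COc2cccc(-c3ccc(F)nc3F)n2)CCn2cc([N+](=O)[O-])nc2O1`, is reported in this assay only as a limit, > 64000 nM, and not as a number; its 2,6-difluoropyridin-3-yl group is the same group that the new compound carries.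

The compound still to be measured is compound 4, with the structure `O=[N+]([O-])c1cn2c(n1)OC(COc1cccc(-c3ccc(F)nc3F)n1)CC2`. It differs from compound 3 as follows: fluoro in place of hydrogen on an aromatic carbon.

Among the compounds with values here, only one measured step alters this aryl group, namely a 1.7-fold lower number from compound 2 to compound 3 (0.23 log units; within the scatter), and it stayed within the scatter. On that basis no movement beyond the scatter is expected in this assay from the added fluoro, though the limit reported for compound 1 the limit of > 64000 nM in this assay, at which 1 of the 3 values shown sits, leaves room for a somewhat higher number. Compound 4 is therefore estimated at 45000 nM, within a range of 20000 nM to 100000 nM, which corresponds to an expected step of a 1.3-fold higher number from compound 3 to compound 4 (0.11 log units; within the scatter).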

Compound 4, half-maximal inhibitory concentration: > 64000 nM
Compound 4 ended at the assay's limit; the forecaster's own chance of this, stated with the estimate: 30%; at least 1.4-fold (0.15 log units) between middle value and limit.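

In this assay compound 4 gives > 64000 nM, which is a limit of the assay and not a number. With the fluoro on the aromatic carbon next to the ring nitrogen, the result is an at least 1.8-fold higher number from compound 3 to compound 4 (0.26 log units; that floor lies within the scatter), and with 2,6-difluoropyridin-3-yl in place of 4-fluorophenyl it is an at least 1.0-fold higher number from compound 2 to compound 4 (0.03 log units; that floor lies within the scatter), so neither floor shows a change beyond the scatter, and neither step has a known upper end. Compound 1 and compound 4, which differ by a methyl on a saturated ring carbon, both end at the limit, so the step between them cannot be read, and the 2,6-difluoropyridin-3-yl group has yielded no number among the compounds shown: the limit of > 64000 nM in this assay, at which 2 of the 4 values shown sit.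

How far compound 4 lies past the limit stays unknown, so the compounds shown do not tell whether the added fluoro changes the number at all. Nor do they tell what an amine or a methoxy group in place of that fluoro, next to the ring nitrogen, would give in this assay.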